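The compounds below may be only part of what the source reports. "The series", "measured", "known", "first", "only" and "open" are said of these compounds alone.

Of the compounds shown here, two of a shared core have so far been tested in a functional assay on MCF7 cells (Homo sapiens) for inhibition, read by MTT assay, with a stated time of 72 h; a lower number here means a stronger inhibitor, a higher number a weaker inhibitor. Compound 1 `Cc1ccc(NC(=O)c2ccc(/N=N\c3c[nH]c4ccccc34)cc2)cc1` gives 42400 nM. Compound 2 `O=C(Nc1ccc(Cl)cc1)c1ccc(/N=N\c2c[nH]c3ccccc23)cc1` gives 107000 nM. Among these two numbers, compound 2 stands highest, which here means the weaker inhibitor: the move a 2.5-fold higher number from compound 1 to compound 2 (0.40 log units; beyond the scatter) was a modest rise, beyond the usual scatter of the measurement.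

The next compound, compound 3 `Cc1cccc(NC(=O)c2ccc(/N=N\c3c[nH]c4ccccc34)cc2)c1`, differs from compound 2 in a single spot: 3-methylphenyl in place of 4-chlorophenyl on an amide-type nitrogen. Among the measured compounds shown here, only one measured step speaks to this change, the one from compound 1 to compound 2, in which a chloro replaced a methyl on the same outer ring and the number rose by a modest margin. Compound 3 brings a methyl back onto that ring, though at a different spot, so a partial reversal of that rise is the natural expectation, with the number expected to fall by roughly a 2.1-fold lower number from compound 2 to compound 3 (0.33 log units; beyond the scatter) in this assay.

On that basis compound 3 is expected to give about 50000 nM in this assay, with a plausible range from 20000 nM to 130000 nM.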

Compound 3, half-maximal inhibitory concentration: 73400 nM
Compound 3: middle estimate off by 1.5-fold (0.17 log units), on the low side; low and high end bracket the measured number.
By their numbers in this assay, from the lowest: compounds 1, 3 and 2 (each within the scatter of the next, the first and the last beyond it).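

Replacing 4-chlorophenyl with 3-methylphenyl on the amide-type nitrogen gives a 1.5-fold lower number from compound 2 to compound 3 (0.16 log units; within the scatter) in this assay, and replacing 4-methylphenyl with 3-methylphenyl at the same place gives a 1.7-fold higher number from compound 1 to compound 3 (0.24 log units; within the scatter). Among the compounds shown here, compound 3 therefore cannot be told apart from either of the other two compounds, even though those two are separated by a 2.5-fold higher number from compound 1 to compound 2 (0.40 log units; beyond the scatter), so the 4-methylphenyl to 4-chlorophenyl change remains the only step here that clearly exceeds the scatter, and moving the methyl around the ring produces no readable change in this small set. No accompanying measurement offers an explanation for these numbers.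

The compounds shown leave open whether a quite different group on this ring, such as a methoxy group, an amine or a carboxylic acid, would shift the number well beyond the scatter in either direction. They also leave open whether a chloro placed where compound 3 carries its methyl would read like compound 2 or like compound 3.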